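A Thiourea in Place of the Cyanoguanidine on a Shared Core

The source may report more compounds than this note shows. Statements on the series, on what has been measured and on what is new or still open speak of the compounds shown alone.

Compound 1 `N#CNC(=N)NCCCCCn1nc(-c2ccccc2)ccc1=O`: in a functional assay on the whole organism (stomach) with Rattus norvegicus as the target (on this read-out lower numbers stand for an effect already at smaller amounts and higher numbers for an effect only at larger amounts of compound), compound 1 gives > 100 mg/kg, a limit of the assay.
Compound 2 `CC/N=C(/NC#N)NCCCCn1nc(-c2ccccc2)ccc1=O`: in this assay compound 2 gives 92 mg/kg.
Compound 3 `CCC/N=C(/NC#N)NCCCCn1nc(-c2ccccc2)ccc1=O`: in this assay compound 3 gives > 100 mg/kg, a limit of the assay.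

Compound 3 thus stands at the limit of > 100 mg/kg in this assay, at which 2 of the 3 values shown sit. The two measured steps, an at least 1.0-fold lower number from compound 1 to compound 2 (0.03 log units; that floor lies within the scatter) and an at least 1.0-fold higher number from compound 2 to compound 3 (0.03 log units; that floor lies within the scatter), reach only their floors, and both lie within the scatter. Compound 4 `C/N=C(\S)NCCCCn1nc(-c2ccccc2)ccc1=O` differs from compound 3 by a group of 4 heavy atoms (2 carbon, 1 nitrogen, 1 sulfur; no ring) in place of a group of 8 heavy atoms (5 carbon, 3 nitrogen; no ring), on an amine nitrogen. Neither measured step touches this place; both run over the alkyl part. Among the measured compounds shown here, no step therefore sets a direction beyond the scatter in this assay. Compound 4 is expected at 100 mg/kg, with a range from 35 mg/kg to 300 mg/kg. That estimate is expected to mean a number no higher from compound 3 to compound 4 (the limit leaves the size open).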

Compound 4, dose for half-maximal effect: 28.9 mg/kg
Compound 4: middle estimate off by 3.5-fold (0.54 log units), on the high side; measured number below the stated range.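

In this assay the change on the amine nitrogen sets the first direction beyond the scatter, with an at least 3.4-fold lower number from compound 3 to compound 4 (0.53 log units; beyond the scatter) and a 3.2-fold lower number from compound 2 to compound 4 (0.50 log units; beyond the scatter) where the alkyl steps had set none. On a saturated chain carbon, four bonds along the chain from an aromatic nitrogen, an at least 3.4-fold lower number from compound 1 to compound 4 (0.53 log units; beyond the scatter) runs the same way. Two of these three steps give only floors, not full sizes: the limit of > 100 mg/kg in this assay, at which 2 of the 4 values shown sit.

Open, from the compounds shown here alone, is whether an ethyl or propyl group on the thiourea would hold this level, and whether a urea, with oxygen in place of sulfur, would match compound 4.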